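Fluoro to Chloro: What Happens to Half-Life?

The compounds below may be only part of what the source reports. "The series", "measured", "known", "first", "only" and "open" are said of these compounds alone.

compound 1 `Cc1cccc2c(-c3ccc4ccc(F)cc4n3)c[nH]c12` gives 0.883 h
compound 2 `Clc1cccc2c(-c3ccc4ccccc4n3)c[nH]c12` gives 0.283 h

In an ADME assay on microsomes from liver (Homo sapiens) for metabolic stability, using NADPH, with a stated time of 40 min, tested at 2 uM (on this read-out higher numbers stand for a longer-lived compound and lower numbers for a shorter-lived compound), compound 1 stands highest of the two at 0.883 h, and compound 2 gives 0.283 h. The gap between these two numbers lies beyond the usual scatter. Compound 3 `Cc1cccc2c(-c3ccc4ccc(Cl)cc4n3)c[nH]c12` has chloro in place of fluoro on an aromatic carbon of compound 1 (chloro in place of fluoro on an aromatic carbon). For the measured compounds named here, no measured pair shows this swap, so its size in this assay remains a judgement. The expected change is a 1.3-fold lower number from compound 1 to compound 3 (0.10 log units; within the scatter), a small fall that stays within the usual scatter. For compound 3 the estimated half-life is 0.7 h, with an expected range from 0.3 h to 1.6 h.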

Compound 3, half-life: 1.48 h
Compound 3: the middle estimate sits 2.1-fold (0.33 log units) below what was measured; the range from low to high includes it.
By their numbers in this assay, from the lowest: compound 2; then compounds 1 and 3 (each within the scatter of the next).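

Putting chloro in place of fluoro on this aromatic carbon gives a 1.7-fold higher number from compound 1 to compound 3 (0.22 log units; within the scatter) in this assay. For the compounds shown here, this is the first direct look at this position, and at this swap, and the two halogens cannot be told apart on half-life, so here chloro serves as well as fluoro. Nothing measured here offers a reason for this result.

Still open, as far as these compounds go, is whether a different kind of group on this aromatic carbon, such as a methoxy group or an amine, would give a half-life clearly different from that of compound 1.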